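The source may hold more compounds than are shown below. What is called first, only, known or untested is meant among the compounds shown, and "the series" means these compounds.

Compound 1 `O=C(O)/C=C/C(=O)Nc1ccc(C(=O)O)c(Nc2cccc(C(F)(F)F)c2)c1` and compound 2 `O=C(CCCO)Nc1ccc(C(=O)O)c(Nc2cccc(C(F)(F)F)c2)c1` share one core. In an assay on urine for inhibition of Myeloperoxidase (Homo sapiens) (a lower number here means a stronger inhibitor, a higher number a weaker inhibitor), compound 1 returns only a limit of the assay, > 100000 nM. In this assay compound 2 likewise returns a limit, > 100000 nM. The step that the two limits leave unreadable from compound 1 to compound 2 therefore stays unreadable, and the limit of > 100000 nM in this assay, at which 2 of the 2 values shown sit, is all the two values show. Compound 3 `NCCCC(=O)Nc1ccc(C(=O)O)c(Nc2cccc(C(F)(F)F)c2)c1` differs from compound 2 by amino in place of hydroxy on a saturated chain carbon, three bonds along the chain from a carbonyl carbon. Within the data shown here, no measured step bears on this change, and both reference values are limits, so no shift beyond the scatter is expected; the step that the limit leaves unreadable from compound 2 to compound 3 is an estimate only. For compound 3 the expected value is 150000 nM, within 40000 nM to 600000 nM.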

Compound 3, half-maximal inhibitory concentration: 5500 nM
For compound 3 the middle estimate is 27-fold (1.44 log units) above the measured one; the measured number lies below the stated range.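

In this assay, among these compounds, amino in place of hydroxy on a saturated chain carbon, three bonds along the chain from a carbonyl carbon, is the first readable change at this position: an at least 18-fold lower number from compound 2 to compound 3 (1.25 log units; beyond the scatter). The 3-aminopropyl group also separates clearly from the 2-carboxyethenyl group, with an at least 18-fold lower number from compound 1 to compound 3 (1.25 log units; beyond the scatter). Compound 1 and compound 2 remain at a limit of the assay: the limit of > 100000 nM in this assay, at which 2 of the 3 values shown sit.

Open, going by these compounds, is how the value moves when the amine sits on a shorter 2-aminoethyl chain or on a longer chain. Also open, on these data alone, is whether a dimethylamino group in its place keeps the step.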